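The source may hold more compounds than are shown below. What is called first, only, known or untested is meant among the compounds shown, and "the series" means these compounds.

Measured compounds:
compound 1, `COC(=O)C[C@@H]1NC(=O)[C@@H](C)NC(=O)[C@@H]2Cc3ccc(OC)c(c3)Oc3ccc(cc3)C[C@@H](C(=O)N2C)N(C)C(=O)[C@H](C)NC(=O)[C@H](Cc2ccc(OC)cc2)N(C)C1=O`: 41.7 nM
compound 2, `CCCN1C(=O)[C@@H](C)NC(=O)[C@@H]2Cc3ccc(OC)c(c3)Oc3ccc(cc3)C[C@@H](C(=O)N2C)N(C)C(=O)[C@H](C)NC(=O)[C@H](Cc2ccc(OC)cc2)N(C)C(=O)[C@@H]1C`: 3.98 nM

Of the compounds shown here, two have been measured in a functional assay on P388 cells (Mus musculus) for cytotoxicity; a lower number here means a stronger inhibitor, a higher number a weaker inhibitor. In it compound 1 gives 41.7 nM, and compound 2 gives 3.98 nM. Within the data shown here, of these two numbers, compound 2 has the lower one, and its only neighbour, compound 1, sits a clear distance away, well beyond the usual scatter. The two compounds differ in more than one place, so their pair says nothing about any single structural change.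

Compound 3, `CCCCCN1C(=O)[C@@H](C)NC(=O)[C@@H]2Cc3ccc(OC)c(c3)Oc3ccc(cc3)C[C@@H](C(=O)N2C)N(C)C(=O)[C@H](C)NC(=O)[C@H](Cc2ccc(OC)cc2)N(C)C(=O)[C@@H]1C`, has not yet been measured. It is derived from compound 2 by one change: ethyl in place of hydrogen on a saturated chain carbon, three bonds along the chain from an amide-type nitrogen in a ring. Among the measured compounds shown here, no step between two measured compounds that differ in a single place is known, so the size of this step in this assay must be judged from the change alone. Lengthening a chain by this small amount tends to move a number of this kind only a little, in either direction, and no shift beyond the scatter is expected. Compound 3 is therefore expected to give about 5 nM, within a range from 1.5 nM to 20 nM. This estimate means an expected step of a 1.3-fold higher number from compound 2 to compound 3 (0.10 log units; within the scatter), which would stay inside the scatter.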

Compound 3, half-maximal inhibitory concentration: 21.4 nM
Estimate against measurement, compound 3: 4.3-fold (0.63 log units) below, and the stated range ends below it.
By their numbers in this assay, from the lowest: compound 2; then compounds 3 and 1 (each within the scatter of the next).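

In this assay, putting ethyl in place of hydrogen on a saturated chain carbon, three bonds along the chain from an amide-type nitrogen in a ring, turns propyl into pentyl and brings a 5.4-fold higher number from compound 2 to compound 3 (0.73 log units; beyond the scatter). Among these compounds, this is the first single change that can be read, since compound 1 and compound 2 differ in more than one place, and it shows that the length of this chain matters: a higher number means a weaker inhibitor, so the longer chain gives up a modest amount of strength. No measurement at hand speaks to what lies behind this step.

Among the compounds shown here, with only two chain lengths to compare, the shape of the trend remains open: butyl would show whether the number climbs gradually from propyl to pentyl, and hexyl whether it keeps climbing beyond that. On these data alone, it also remains open whether this place responds to chain length alone or also to what the chain carries, which a propyl chain ending in an amine or a carboxylic acid would help to settle.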